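Cytotoxicity notes on a thiosemicarbazone series

This account rests on a few compounds, and the source may have more. Where it says the series, first, only, none or still open, it means among the compounds named here.

Measured so far in an ADME assay on Vero cells (Chlorocebus sabaeus) for cytotoxicity; a lower number here means that less compound is tolerated, a higher number that more compound is tolerated:
compound 1, `CCN(CC)CN1C(=O)/C(=N/NC(=S)Nc2ccc(Cl)cc2)c2ccccc21`, gives 20000 nM
compound 2, `CCN(CC)CN1C(=O)/C(=N/NC(=S)Nc2ccc(C)cc2)c2ccccc21`, gives 100000 nM
compound 3, `CCN(CC)CN1C(=O)/C(=N/NC(=S)Nc2ccc(C)cc2)c2cc(Cl)ccc21`, gives >= 4000 nM

The value for compound 3 is a limit of this assay, not a number, as recorded in the limit of >= 4000 nM in this assay, at which 1 of the 3 values shown sits. Between compound 2 and compound 1 the change is chloro in place of methyl on an aromatic carbon, and the step is a 5.0-fold lower number from compound 2 to compound 1 (0.70 log units; beyond the scatter). Between compound 2 and compound 3 the change is chloro in place of hydrogen on an aromatic carbon, and here a step that the limit leaves unreadable from compound 2 to compound 3.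

Compound 4, `CCN(CC)CN1C(=O)/C(=N/NC(=S)Nc2ccc(Cl)cc2)c2cc(Cl)ccc21`, is not yet measured in this assay. It differs from compound 3 by chloro in place of methyl on an aromatic carbon, the same change as from compound 2 to compound 1, with the same surroundings at the place of the change; the two cores differ by chloro in place of hydrogen on an aromatic carbon.

For compound 4 the expected step is a step that the limit leaves unreadable from compound 3 to compound 4, which rests on the earlier step of a 5.0-fold lower number from compound 2 to compound 1 (0.70 log units; beyond the scatter). Because for compound 3 only the limit >= 4000 nM is known, the starting point is itself uncertain. Compound 4 is therefore expected at about 8000 nM, with a range from 2000 nM to 40000 nM.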

Compound 4, minimum cytotoxic concentration: 100000 nM
Beside the measured number, compound 4's estimate is 13-fold (1.10 log units) below it, and the stated range ends below it.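

In this assay, among these compounds, the one new step that can be read is chloro in place of hydrogen on an aromatic carbon of the core, with the 4-chlorophenyl group held fixed, and it gives a 5.0-fold higher number from compound 1 to compound 4 (0.70 log units; beyond the scatter) in the working series. This does not show whether the step of chloro in place of methyl seen on the first core, a 5.0-fold lower number from compound 2 to compound 1 (0.70 log units; beyond the scatter), carries over to the core of compound 3, neither confirming that nor ruling it out, and a single pair of cores would make no pattern in any case. The steps that start from or end at compound 3 cannot be read because compound 3 is held only as a limit, not a number: the limit of >= 4000 nM in this assay, at which 1 of the 4 values shown sits.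

A number for compound 3 would settle whether the change carries over. The compounds shown also leave open how the series responds when an amine, a carboxylic acid or a longer chain stands in place of the methyl or chloro on the phenyl group.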